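Pyridinyl acrylamide series: CDK8/Cyclin C single-point inhibition

The compounds below may be only part of what the source reports. "The series", "measured", "known", "first", "only" and "open" are said of these compounds alone.

Measured so far:
compound 1 `Cn1ccc2cc(-c3cnccc3/C=C/C(=O)O)ccc21`, 102%
compound 2 `O=C(O)[C@@H]1CCCN1C(=O)/C=C/c1ccncc1-c1ccc2ccccc2c1`, 67%
compound 3 `Cn1ncc2cc(-c3cnccc3/C=C/C(=O)O)ccc21`, 102%

In an assay on a protein complex for inhibition of CDK8/Cyclin C (Homo sapiens), with a stated time of 1 h, tested at 10 uM (on this read-out higher numbers stand for more inhibition at the one concentration tested (going by the name of the read-out) and lower numbers for less inhibition), compound 2 stands lowest of the three numbers. Compound 1 gives 102% and compound 3 gives 102%; both lie the same distance above compound 2, a gap beyond the usual scatter, while compound 1 and compound 3 sit within the scatter of each other.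

The next compound is compound 4 `CN(C)C(=O)/C=C/c1ccncc1-c1ccc2ccccc2c1`. Its change from compound 2 is dimethylamino in place of 2-carboxypyrrolidin-1-yl on a carbonyl carbon.

Among the measured compounds shown here, no step between measured compounds covers this change. The expected step in this assay is a number 27 percentage points lower from compound 2 to compound 4 (beyond the scatter), a decrease beyond the scatter, because compound 2 already gives 67% as the lowest number shown. Compound 4 is estimated at 40%, expected to fall between 10% and 70%.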

Compound 4, a percentage reported as inhibition, at one concentration (the size of the read-out at that concentration, not a potency): 100%
The estimate for compound 4 lay 60 percentage points below the measured number; measured number above the stated range.
By their numbers in this assay, from the lowest: compound 2; then compounds 4, 1 and 3 (each within the scatter of the next).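

In this assay, the one-place change on the carbonyl carbon, dimethylamino in place of 2-carboxypyrrolidin-1-yl, gives a number 33 percentage points higher from compound 2 to compound 4 (beyond the scatter). This shows that the number depends on the group at this position, and that the carboxylic acid, the ring and the defined stereocentre of 2-carboxypyrrolidin-1-yl are not needed for a high number on the core of compound 4. Nothing available explains the step.

This single pair does not separate the contributions of the ring and the carboxylic acid; an unsubstituted pyrrolidin-1-yl group would address that. Also open, from the compounds shown here alone, is how diethylamino, with its longer chains, would read at this position.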